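The source may hold more compounds than are shown below. What is called first, only, known or untested is meant among the compounds shown, and "the series" means these compounds.

Series notes. Compound 1 `CC1(C)CCC(CN2CCN(c3ccc(C(=O)NS(=O)(=O)c4ccc(NCC5CCOCC5)c([N+](=O)[O-])c4)c(Oc4cnc5[nH]ccc5c4)c3)CC2)=C(c2ccc(C(F)(F)F)cc2)C1` is the reference point. Among the compounds with values here, in an assay on isolated protein for displacement of a labelled ligand from Apoptosis regulator Bcl-2 (Homo sapiens), with a stated time of 15 min (on this read-out higher numbers stand for weaker inhibition and lower numbers for stronger inhibition), compound 1 gives 1.5 nM, the lowest of the three numbers measured so far. Compound 2 `COc1ccc(C2=C(CN3CCN(c4ccc(C(=O)NS(=O)(=O)c5ccc(NCC6CCOCC6)c([N+](=O)[O-])c5)c(Oc5cnc6[nH]ccc6c5)c4)CC3)CCC(C)(C)C2)cc1` gives 3.8 nM in this assay, and a 2.5-fold higher number from compound 1 to compound 2 (0.40 log units; beyond the scatter). Compound 3 `CN1CCC(CNc2ccc(S(=O)(=O)NC(=O)c3ccc(N4CCN(CC5=C(c6ccc(C(F)(F)F)cc6)CC(C)(C)CC5)CC4)cc3Oc3cnc4[nH]ccc4c3)cc2[N+](=O)[O-])C1` gives 2.4 nM in this assay, and a 1.6-fold higher number from compound 1 to compound 3 (0.20 log units; within the scatter).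

Compound 4 `CC(C)C(=O)N1CCC(CNc2ccc(S(=O)(=O)NC(=O)c3ccc(N4CCN(CC5=C(c6ccc(C(F)(F)F)cc6)CC(C)(C)CC5)CC4)cc3Oc3cnc4[nH]ccc4c3)cc2[N+](=O)[O-])CC1` differs from compound 1 in one place: 1-(isopropylcarbonyl)piperidin-4-yl in place of oxan-4-yl on a saturated chain carbon bound to a nitrogen on an aromatic ring. Within the data shown here, only one measured step touches this position: a 1.6-fold higher number from compound 1 to compound 3 (0.20 log units; within the scatter), a swap of one saturated ring for another on the same chain carbon, which left the number within the scatter. The change into compound 4 keeps a six-membered non-aromatic ring with one hetero atom and adds the isopropylcarbonyl group; nothing measured speaks to that group itself. The expectation is therefore a small step at most, none beyond the scatter, and in this assay the estimated step is a 1.7-fold higher number from compound 1 to compound 4 (0.22 log units; within the scatter). Compound 4 is expected at 2.5 nM, with a range from 1 nM to 6.5 nM.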

Compound 4, half-maximal inhibitory concentration: 2.4 nM
The estimate for compound 4 lay 1.0-fold (0.02 log units) above the measured number; the range from low to high includes it.
By their numbers in this assay, from the lowest: compounds 1, 3, 4 and 2 (each within the scatter of the next, the first and the last beyond it).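

In this assay, this position accepts 1-(isopropylcarbonyl)piperidin-4-yl, with 11 heavy atoms in place of the 6 of oxan-4-yl, at a 1.6-fold higher number from compound 1 to compound 4 (0.20 log units; within the scatter). Set against the 1-methylpyrrolidin-3-yl group, the same group gives no change at the digits printed from compound 3 to compound 4 (within the scatter), so compounds 1, 3 and 4 all lie within the scatter of one another despite three different groups on this saturated chain carbon. No measurement on hand accounts for this tolerance.

As far as these compounds go, it remains open whether a carboxylic acid or a primary amine on the ring at this position, or a longer chain in place of the isopropyl group, would stay in the same range. Also open, from the compounds shown here alone, is what the isopropylcarbonyl group contributes apart from the ring that carries it.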